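The source may hold more compounds than are shown below. What is called first, only, known or untested is meant among the compounds shown, and "the series" means these compounds.

Of the compounds shown here, two have been measured in a physicochemical assay for lipophilicity; on this read-out higher numbers stand for higher lipophilicity and lower numbers for lower lipophilicity. Compound 1, `CS(=O)(=O)Cc1cc([C@]23CCOC[C@H]2C3)nc(-c2cccc(O)c2)n1`, gives 3.7. Compound 2, `CCNC(=O)Nc1ccc(-c2nccc(C3=CCOCC3)n2)cc1`, gives 3.6, and the gap between these two values lies within the usual scatter of the measurement, so the data do not separate them. Compound 3, `CCNC(=O)Nc1ccc(-c2nccc([C@]34CCOC[C@H]3C4)n2)cc1`, shares its core with compound 2 and has not yet been measured in this assay. The change from compound 2 to compound 3 is a group of 7 heavy atoms (6 carbon, 1 oxygen; one three-membered non-aromatic ring of carbon only, one six-membered non-aromatic ring with 1 hetero atom) in place of a group of 6 heavy atoms (5 carbon, 1 oxygen; one six-membered non-aromatic ring with 1 hetero atom), on an aromatic carbon. Among the measured compounds shown here, no measured pair in this set differs in one place, so the size of such a step is not known from a direct comparison; compound 1 carries the entering group, but on a different core, which does not settle the matter. In this assay the expected step is a number 0.30 log units higher from compound 2 to compound 3 (within the scatter), small and upward, at the edge of the scatter. For compound 3 the estimate in this assay is 3.9, with a range from 3.5 to 4.3.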

Compound 3, partition coefficient: 3.9
For compound 3 middle estimate and measured number coincide at the digits printed, within the range that was stated.
By their numbers in this assay, from the lowest: compounds 2, 1 and 3 (each within the scatter of the next).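

In this assay the group carrying the three-membered carbon ring, put in place of the group with the double bond outside aromatic rings on the aromatic carbon next to the ring nitrogen, gives a number 0.30 log units higher from compound 2 to compound 3 (within the scatter) on the shared core. Among the compounds shown here, this is the first direct reading of a change at this position, which the earlier pair could not give since compound 1 and compound 2 differ in more than one place, and it shows that this exchange, which adds one heavy atom and leaves the hydrogen-bond donor and acceptor counts of the group unchanged, does not separate compound 2 from compound 3 on this read-out. Nothing measured here accounts for the size of the step.

Because this single step stays within the scatter, the compounds shown leave open whether the exchange has any real effect on this read-out, and whether it would read the same on the core of compound 1. They also leave open what a group of another kind at this aromatic carbon, such as an amine or a carboxylic acid, would do to the number.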